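Trifluoromethylpyrimidine to fused bicycle on the ether oxygen

The compounds below may be only part of what the source reports. "The series", "measured", "known", "first", "only" and "open" are said of these compounds alone.

Compound 3 `CC(C)[C@H](NC(=O)COc1cccc2ccccc12)C(=O)N[C@@H](CC(=O)O)C(=O)COc1cc(C(F)(F)F)ncn1` sits at the floor of a functional assay on Jurkat cells (Homo sapiens) for inhibition; a lower number here means a stronger inhibitor, a higher number a weaker inhibitor: in this assay compound 3 gives > 200000 nM, which is a limit and not a number. Compound 1 `CC(C)[C@H](NC(=O)COc1cccc2ccccc12)C(=O)N[C@@H](CC(=O)O)C(=O)CSc1nc2ccccc2s1` also sits at a limit, giving > 200000 nM in this assay. Going by the values given here, compound 2 `CC(C)[C@H](NC(=O)COc1cccc2ccccc12)C(=O)N[C@@H](CC(=O)O)C(=O)COc1ccnc(C(F)(F)F)n1` is the only one with a number; in this assay compound 2 gives 37000 nM. The measured steps are an at least 5.4-fold lower number from compound 1 to compound 2 (0.73 log units; beyond the scatter) and an at least 5.4-fold higher number from compound 2 to compound 3 (0.73 log units; beyond the scatter), while a step that the two limits leave unreadable from compound 1 to compound 3 cannot be read because of the limit of > 200000 nM in this assay, at which 2 of the 3 values shown sit. Compound 4 `CC(C)[C@H](NC(=O)COc1cccc2ccccc12)C(=O)N[C@@H](CC(=O)O)C(=O)COc1[nH]cnc2nncc1-2` differs from compound 3 by a group of 9 heavy atoms (5 carbon, 4 nitrogen; one five-membered aromatic ring with 2 hetero atoms, one six-membered aromatic ring with 2 hetero atoms) in place of a group of 10 heavy atoms (5 carbon, 2 nitrogen, 3 fluorine; one six-membered aromatic ring with 2 hetero atoms), on an oxygen on a saturated carbon. Among the compounds with values here, no measured step swaps this kind of group; the steps only show that the series stays weak throughout. Compound 4 is therefore expected to remain weak, at an estimated 100000 nM within a range of 20000 nM to 300000 nM. Compound 4 is thus expected to show an at least 2.0-fold lower number from compound 3 to compound 4 (0.30 log units; that floor lies within the scatter).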

Compound 4, half-maximal inhibitory concentration: 161000 nM
Beside the measured number, compound 4's estimate is 1.6-fold (0.21 log units) below it, and the stated range covers the measured number.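

In this assay, compound 4 gives this position a second true number, so two groups on an oxygen on a saturated carbon can now be compared directly: a 4.4-fold higher number from compound 2 to compound 4 (0.64 log units; beyond the scatter). The 2-(trifluoromethyl)pyrimidin-4-yl group of compound 2 thus stays ahead of the new two-ring group, which does not bring the series closer to strong inhibition. Against the two limit compounds, an at least 1.2-fold lower number from compound 3 to compound 4 (0.09 log units; that floor lies within the scatter) and an at least 1.2-fold lower number from compound 1 to compound 4 (0.09 log units; that floor lies within the scatter) give only floors and fix no order: the limit of > 200000 nM in this assay, at which 2 of the 4 values shown sit.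

From the compounds shown here alone, whether a plain phenyl or pyridyl ring on that oxygen would fall nearer compound 2 remains open. So does whether any group here could give much stronger inhibition.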